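Methoxy or Fluoro on the Pendant Phenyl Ring

The source may report more compounds than this note shows. Statements on the series, on what has been measured and on what is new or still open speak of the compounds shown alone.

The series shares one core and differs only in the aryl group attached to it. Compound 1 `COc1ccc(-c2cn3ccnc3c(-c3ccc4ncn(C5CCCCC5)c4c3)n2)cc1` carries a 4-methoxyphenyl group; in a functional assay on LOX IMVI cells (Homo sapiens) for inhibition, read by sulforhodamine B assay, with a stated time of 48 h, tested at 10 uM (a higher number here means more inhibition at the concentration tested (going by the name of the read-out), a lower number less inhibition), compound 1 gives 69.6%. Compound 2 `Fc1ccc(-c2cn3ccnc3c(-c3ccc4ncn(C5CCCCC5)c4c3)n2)cc1` differs by fluoro in place of methoxy on an aromatic carbon, and in this assay compound 2 gives 3.5%, a step of a number 66.1 percentage points lower from compound 1 to compound 2 (beyond the scatter). Compound 3 `COc1ccccc1-c1cn2ccnc2c(-c2ccc3ncn(C4CCCCC4)c3c2)n1` differs from compound 1 by 2-methoxyphenyl in place of 4-methoxyphenyl on an aromatic carbon, and compound 3 gives 5.13%, a step of a number 64.5 percentage points lower from compound 1 to compound 3 (beyond the scatter); between compound 2 and compound 3 the step is a number 1.6 percentage points higher from compound 2 to compound 3 (within the scatter).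

Compound 4 `Fc1ccccc1-c1cn2ccnc2c(-c2ccc3ncn(C4CCCCC4)c3c2)n1` is not yet measured. It differs from compound 3 by fluoro in place of methoxy on an aromatic carbon. This is the same kind of change as from compound 1 to compound 2, but the place differs: para to a large group in the earlier pair, ortho to a large group here. Because the earlier step of a number 66.1 percentage points lower from compound 1 to compound 2 (beyond the scatter) fell to a low number and compound 3 already gives 5.13%, the expected step is a number 0.1 percentage points lower from compound 3 to compound 4 (within the scatter). For compound 4 the estimate is 5%, expected between -5% and 25%.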

Compound 4, a percentage reported as inhibition, at one concentration (the size of the read-out at that concentration, not a potency): 5.77%
The estimate for compound 4 lay 0.8 percentage points below the measured number; measured number inside the range.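

In this assay, the exchange of methoxy for fluoro did not carry from one core to the other, and the two steps differ: the same change on two cores in this assay, a number 66.1 percentage points lower (beyond the scatter) from compound 1 to compound 2 and a number 0.6 percentage points higher (within the scatter) from compound 3 to compound 4, 66.7 percentage points apart, beyond the scatter of two such steps

The new step, a number 0.6 percentage points higher from compound 3 to compound 4 (within the scatter), shows that the large drop seen with the 4-methoxyphenyl group does not recur with the 2-methoxyphenyl group, while a number 2.3 percentage points higher from compound 2 to compound 4 (within the scatter) and a number 63.8 percentage points lower from compound 1 to compound 4 (beyond the scatter) leave only compound 1 apart from the other three. This does not show why the steps differ, and since compound 3 already gives a low number, the pair cannot tell whether fluoro would lower a higher number at that place; two pairs also give no rule for other cores.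

The compounds shown leave open whether the high number of compound 1 belongs to methoxy alone or would also appear with another group in its place, such as ethoxy, an amine or a carboxylic acid. They also leave open whether the cyclohexyl group plays any part, as it is the same in all four compounds.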